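The source may report more compounds than this note shows. Statements on the series, on what has been measured and on what is new or still open speak of the compounds shown alone.

Three compounds have been measured in a functional assay on M21 cells (Homo sapiens) for cytotoxicity, read by sulforhodamine B assay, with a stated time of 48 h; a higher number here means a weaker inhibitor, a lower number a stronger inhibitor:

compound 1, `O=C(NCCCCl)Nc1cccc(S(=O)(=O)Oc2ccc(O)cc2)c1`, 49000 nM
compound 2, `Cc1ccccc1NS(=O)(=O)c1ccc(NC(=O)NCCCCl)cc1`, which gives only a limit of the assay, > 200000 nM
compound 3, `CCNC(=O)Nc1cccc(S(=O)(=O)Oc2ccc(O)cc2)c1`, 42000 nM

Compound 1 and compound 3 share one core and differ in a single place: hydrogen in place of chloromethyl on a saturated chain carbon, two bonds along the chain from an amide-type nitrogen. In this assay this change made a 1.2-fold lower number from compound 1 to compound 3 (0.07 log units; within the scatter), so the two values sit together and no order between them can be read.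

Compound 2 rests on another core, and the difference between the two cores is not broken down here. Going by the values given here, for compound 2 this assay reports a limit rather than a number, and it is the one value that sits at the limit of > 200000 nM in this assay, at which 1 of the 3 values shown sits.

Compound 4, `CCNC(=O)Nc1ccc(S(=O)(=O)Nc2ccccc2C)cc1`, has not yet been measured in this assay. It differs from compound 2 by hydrogen in place of chloromethyl on a saturated chain carbon, two bonds along the chain from an amide-type nitrogen, the same change that separates compound 1 from compound 3, at the same place on the chain. Because that change gave a 1.2-fold lower number from compound 1 to compound 3 (0.07 log units; within the scatter) on the first core, the step to compound 4 is expected to be small as well, about a number no higher from compound 2 to compound 4 (the limit leaves the size open). Compound 4 is therefore estimated at 200000 nM, with a range from 80000 nM to 500000 nM, and it is considered likely that this assay will again report only a limit for compound 4 rather than a number.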

Compound 4, half-maximal inhibitory concentration: > 200000 nM
Compound 4 gave a limit, no number; the forecaster's own chance of this, stated with the estimate: 75%; the middle value lies on the limit itself.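

Compound 4 gives only a limit in this assay, > 200000 nM, and not a number. Compound 2 stands at the same kind of limit, so no step between compound 2 and compound 4 can be read: the limit of > 200000 nM in this assay, at which 2 of the 4 values shown sit.

The compounds shown leave open whether hydrogen in place of chloromethyl changes anything on the core of compound 2, and what number either compound would give.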